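From Free Piperazine to a Sulfonylated Nitrogen

This account rests on a few compounds, and the source may have more. Where it says the series, first, only, none or still open, it means among the compounds named here.

In a functional assay on PANC-1 cells (Homo sapiens) for inhibition, read by sulforhodamine B assay, with a stated time of 48 h (a higher number here means a weaker inhibitor of growth, a lower number a stronger inhibitor of growth), compound 3 `c1ccc(-c2nc3ncccn3c2CN2CCNCC2)cc1` gives 9400 nM, the highest number of the three, against compound 2 `c1ccc(-c2nc3ncccn3c2CN2CCCCC2)cc1` at 1310 nM and compound 1 `c1ccc(-c2nc3ncccn3c2CN2CCCC2)cc1` at 60 nM. Compound 4 `Cc1ccc(S(=O)(=O)N2CCN(Cc3c(-c4ccccc4)nc4ncccn34)CC2)cc1` differs from compound 3 by (4-methylphenyl)sulfonyl in place of hydrogen on an amine nitrogen in a ring, with (4-methylphenyl)sulfonyl in place of hydrogen on the amine nitrogen in the ring. The nearest evidence is a 7.2-fold higher number from compound 2 to compound 3 (0.86 log units; beyond the scatter), which is modest, and a 160-fold higher number from compound 1 to compound 3 (2.19 log units; beyond the scatter), which is large. a 22-fold higher number from compound 1 to compound 2 (1.34 log units; beyond the scatter) is also large. All three swap the amine ring, and none substitutes that nitrogen, so they guide the expectation only loosely. The expected change is a 2.4-fold lower number from compound 3 to compound 4 (0.37 log units; beyond the scatter), a modest shift towards a lower number. The estimated value for compound 4 is 4000 nM, within an expected range of 600 nM to 25000 nM.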

Compound 4, concentration for 50% growth inhibition: 110 nM
Beside the measured number, compound 4's estimate is 36-fold (1.56 log units) above it, and the stated range ends above it.
By their numbers in this assay, from the lowest: compounds 1 and 4 (each within the scatter of the next); then compound 2; then compound 3.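

In this assay, (4-methylphenyl)sulfonyl in place of hydrogen on the amine nitrogen in the ring gives an 85-fold lower number from compound 3 to compound 4 (1.93 log units; beyond the scatter), a larger step than the swap from piperidin-1-yl to piperazin-1-yl, a 7.2-fold higher number from compound 2 to compound 3 (0.86 log units; beyond the scatter), and in the opposite direction. The weak number of compound 3 therefore does not hold for the piperazine ring as such, since substitution on this nitrogen alone reverses it. Nothing shown gives a reason for this change. Going by these compounds, whether a smaller group on that nitrogen, such as acetyl or methanesulfonyl, would do the same remains open. So does the part played by the methyl group on the phenyl ring.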